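From Benzyl to Phenyl on a Saturated Chain

A few compounds are considered here, and "the series" means these few. Any claim that something is new, unique, unknown or untested is made for them only; others in the source may bear on it.

For the measured compounds named here, in a functional assay on NCI-H630 cells (Homo sapiens) for cytotoxicity, read by sulforhodamine B assay, with a stated time of 5 days (a higher number here means a weaker inhibitor, a lower number a stronger inhibitor), only two compounds have numbers so far. Compound 2 (`O=C(CCCCCCCCCCc1ccccc1)N[C@H]1CCOC1=O`) reads 66000 nM and holds the higher of the two numbers. Compound 1 (`O=C(CCCCCCCCCCCc1ccccc1)CC(=O)N[C@H]1CCOC1=O`) reads 27000 nM and so sits lower, by a gap beyond the usual scatter. Going by the values given here, these two differ in more than one place, so the pair offers no measured step for a single change.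

Compound 3 (`O=C(CCCCCCCCCc1ccccc1)N[C@H]1CCOC1=O`) has not yet been measured. Against compound 2 it carries phenyl in place of benzyl on a saturated chain carbon, nine bonds along the chain from a carbonyl carbon. With no measured single change to guide the reading, only a small move is expected in this assay, towards a somewhat higher number and within or close to the scatter. Compound 2 at 66000 nM is the anchor for this expectation. The estimated change is a 1.2-fold higher number from compound 2 to compound 3 (0.08 log units; within the scatter) on this reading. Compound 3 is therefore expected at 80000 nM with an estimated span from 35000 nM to 180000 nM as its range.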

Compound 3, half-maximal inhibitory concentration: > 100000 nM
Compound 3 ended at the assay's limit; the forecaster's own chance of this, stated with the estimate: 15%; at least 1.2-fold (0.09 log units) between middle value and limit.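

Compound 3 gives the series its first measured single change, and in this assay compound 3 reads > 100000 nM, which is a limit of the assay and not a number. Phenyl in place of benzyl on a saturated chain carbon, nine bonds along the chain from a carbonyl carbon, yields an at least 1.5-fold higher number from compound 2 to compound 3 (0.18 log units; that floor lies within the scatter), so this position has now been tested, but the result is only a floor and does not by itself establish a real change. The true size of the step cannot be read, and any larger loss would look the same at this position, since the readings stop at this point: the limit of > 100000 nM in this assay, at which 1 of the 3 values shown sits.

The compounds shown leave open how this position would respond to an end group other than benzyl or phenyl, such as an amine or a carboxylic acid on the chain. Compound 1, at 27000 nM, differs from the other two compounds in more than one place, so it cannot show which of its differences sets its value apart.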